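A few compounds are considered here, and "the series" means these few. Any claim that something is new, unique, unknown or untested is made for them only; others in the source may bear on it.

Three related compounds have been tested in a functional assay on MDA-MB-231 cells (Homo sapiens) for antiproliferative activity, read by MTT assay, with a stated time of 24 h; a lower number here means a stronger inhibitor, a higher number a weaker inhibitor. Compound 1, `O=C(NNc1ccccc1Cl)c1ccc(NS(=O)(=O)c2cnc(O)nc2O)cc1`, gives 4010 nM in this assay. Compound 2, `O=C(NNc1cccc(Cl)c1)c1ccc(NS(=O)(=O)c2cnc(O)nc2O)cc1`, differs from compound 1 in one place: 3-chlorophenyl in place of 2-chlorophenyl on an amine nitrogen. That change produced a 4.3-fold higher number from compound 1 to compound 2 (0.64 log units; beyond the scatter). In this assay compound 2 gives 17400 nM. Compound 3, `O=C(NNc1ccccc1Cl)c1ccccc1NS(=O)(=O)c1cnc(O)nc1O`, keeps the 2-chlorophenyl group on the amine nitrogen but the remaining atoms are joined differently; the difference between the two cores is not broken down here. In this assay compound 3 gives 18900 nM, which lies close to the number for compound 2 and further from the number for compound 1.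

Compound 4, `O=C(NNc1cccc(Cl)c1)c1ccccc1NS(=O)(=O)c1cnc(O)nc1O`, has not yet been measured. It relates to compound 3 as compound 2 relates to compound 1: 3-chlorophenyl in place of 2-chlorophenyl on an amine nitrogen. The surroundings of the changed group are described in the same words in both pairs, so this is the same change, and it has been seen only once before among these compounds. For the measured compounds named here, on the core of compound 1 it weakened inhibition, and compound 4 is expected to move in the same direction, because the single comparison available is a 4.3-fold higher number from compound 1 to compound 2 (0.64 log units; beyond the scatter). Since that step rests on one pair and compound 3 already starts from the weakest number of the three, a somewhat smaller step is estimated, a 2.6-fold higher number from compound 3 to compound 4 (0.42 log units; beyond the scatter). Compound 4 is therefore expected to give about 50000 nM in this assay, most plausibly between 18000 nM and 150000 nM.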

Compound 4, half-maximal inhibitory concentration: 11800 nM
Estimate against measurement, compound 4: 4.2-fold (0.63 log units) above; measured number outside the range, below it.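

On the core of compound 3, putting 3-chlorophenyl in place of 2-chlorophenyl on the amine nitrogen gives a 1.6-fold lower number from compound 3 to compound 4 (0.20 log units; within the scatter), so in this assay this pair cannot be told apart, although the same swap made a clear difference on the core of compound 1. The effect of this change therefore depends on the core that carries it, and a step measured on one core could not be carried over to the other as a fixed amount: the same change on two cores in this assay, a 4.3-fold higher number (0.64 log units; beyond the scatter) from compound 1 to compound 2 and a 1.6-fold lower number (0.20 log units; within the scatter) from compound 3 to compound 4, 6.9-fold (0.84 log units) apart, beyond the scatter of two such steps. For the compounds shown here, this shows only that the two cores behave differently for this one swap in this assay; with a single pair on each core, it gives no general rule for the series and does not show which feature of the cores produces the difference.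

As far as these compounds go, it remains open whether other groups on the same amine nitrogen, such as an unsubstituted phenyl or a methoxyphenyl, would also behave differently on the two cores, or whether this is particular to the two chlorophenyl groups. From the compounds shown here alone, it is also open whether the same dependence on the core would appear in a different kind of test, since all four numbers come from this assay.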